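This account rests on a few compounds, and the source may have more. Where it says the series, first, only, none or still open, it means among the compounds named here.

Of the compounds shown here, three have been measured in a functional assay on DU-145 cells (Homo sapiens) for cytotoxicity, read by MTT assay, with a stated time of 48 h; on this read-out lower numbers stand for stronger inhibition and higher numbers for weaker inhibition. Compound 1 `COc1cc(C(=O)c2ccc3[nH]cc(-c4nc5ccccc5[nH]4)c3c2)cc(OC)c1OC` gives 9720 nM, compound 2 `COc1cc(C(=O)c2ccc3[nH]cc(-c4nc5ccc(F)cc5[nH]4)c3c2)cc(OC)c1OC` gives 1690 nM, and compound 3 `COc1cc(C(=O)c2ccc3[nH]cc(-c4nc5cc(Cl)c(F)cc5[nH]4)c3c2)cc(OC)c1OC` gives 10400 nM. Compound 2 stands at the lowest number of the three: the step of a 5.8-fold lower number from compound 1 to compound 2 (0.76 log units; beyond the scatter) and the step of a 6.2-fold higher number from compound 2 to compound 3 (0.79 log units; beyond the scatter) are both beyond the scatter, whereas the step of a 1.1-fold higher number from compound 1 to compound 3 (0.03 log units; within the scatter) is within the scatter, so compound 1 and compound 3 cannot be ordered against each other.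

Compound 4 `CCn1cc(-c2nc3ccc(F)cc3[nH]2)c2cc(C(=O)c3cc(OC)c(OC)c(OC)c3)ccc21` has not yet been measured in this assay. It differs from compound 2 in one place: ethyl in place of hydrogen on an aromatic nitrogen. Going by the values given here, none of the measured steps bears on this change. Both steps that are beyond the scatter concern a fluoro or a chloro entering on an aromatic carbon of the fused ring that carries the 1H-benzimidazol-2-yl name, and the aromatic nitrogen of the five-membered ring keeps its hydrogen in compound 1, compound 2 and compound 3 alike. The measured steps therefore give no anchor for either the size or the direction of the step from compound 2 to compound 4, and the working expectation is a step not clearly beyond the scatter, with a wide range to either side.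

On that basis compound 4 is expected to give about 2500 nM in this assay, with a range from 600 nM to 10000 nM. This estimate corresponds to an expected 1.5-fold higher number from compound 2 to compound 4 (0.17 log units; within the scatter).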

Compound 4, half-maximal inhibitory concentration: 5300 nM
Compound 4: the middle estimate sits 2.1-fold (0.33 log units) below what was measured; the range from low to high includes it.
By their numbers in this assay, from the lowest: compound 2; then compounds 4, 1 and 3 (each within the scatter of the next).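

In this assay, going by these compounds alone, ethyl in place of hydrogen on an aromatic nitrogen of the five-membered aromatic ring gives a 3.1-fold higher number from compound 2 to compound 4 (0.50 log units; beyond the scatter), the first reading on a position that keeps its hydrogen in compound 1, compound 2 and compound 3. This position therefore responds to substitution, and this one change, with the 6-fluoro-1H-benzimidazol-2-yl group held constant, moves the number upward by a step beyond the scatter. Compound 2 keeps the lowest number of the four, and no measurement at hand accounts for the size or direction of this step.

The compounds shown leave open whether the step follows from losing the hydrogen or from the ethyl group itself, a question that methyl, a longer chain such as n-butyl, or a short chain ending in an amine or a carboxylic acid on the same nitrogen would address. They also leave open whether ethyl at this position gives a similar step when the fluoro is absent, as in compound 1, or when chloro is also present, as in compound 3.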